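A few compounds are considered here, and "the series" means these few. Any claim that something is new, unique, unknown or untested is made for them only; others in the source may bear on it.

Compound 1 `COc1cc(C(=O)/C=C/c2cccnc2)cc(CN2CCN(c3ccc(C(C)=O)cc3)CC2)c1O` gives 11300 nM.
Compound 2 `COc1cc(C(=O)/C=C/c2ccccn2)cc(CN2CCN(c3ccc(C(=O)/C=C/c4ccccn4)cc3)CC2)c1O` gives 700 nM.
Compound 3 `CC(=O)c1ccc(N2CCN(Cc3cc(C(=O)/C=C/c4cccn4C)ccc3O)CC2)cc1` gives > 45100 nM, a limit.

These three compounds were tested in a functional assay on HCT-8 cells (Homo sapiens) for cytotoxicity, with a stated time of 3 days; on this read-out higher numbers stand for weaker inhibition of growth and lower numbers for stronger inhibition of growth. Of the two numbers reported, compound 2 has the lowest; the nearest is compound 1, whose value stands well beyond the scatter above it. For compound 3 the assay reports no number but only a limit, (the limit of > 45100 nM in this assay, at which 1 of the 3 values shown sits).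

The step followed here leads from compound 2 to compound 4 `O=C(/C=C/c1ccccn1)c1ccc(N2CCN(Cc3cc(C(=O)/C=C/c4ccccn4)ccc3O)CC2)cc1`. The change is small: hydrogen in place of methoxy on an aromatic carbon. Going by the values given here, no measured pair shows this change on its own, so its size must be guessed. Compound 3 also carries a hydroxy group without a methoxy group, but it differs from compound 2 in more than one place, and its value is a limit, so it does not settle the question.

The account expects compound 4 to lose a little against compound 2, with a step of a 2.1-fold higher number from compound 2 to compound 4 (0.33 log units; beyond the scatter) that is estimated to lie near the edge of the usual scatter. Compound 4 is therefore expected to give 1500 nM, with a range from 500 nM to 5000 nM.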

Compound 4, concentration for 50% growth inhibition: 1260 nM
Beside the measured number, compound 4's estimate is 1.2-fold (0.08 log units) above it, within the range that was stated.
By their numbers in this assay, from the lowest: compounds 2 and 4 (each within the scatter of the next); then compound 1. At a limit, above all of these: compound 3.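

In this assay, going by these compounds alone, hydrogen in place of methoxy on the aromatic carbon ortho to a hydroxy group gives a 1.8-fold higher number from compound 2 to compound 4 (0.26 log units; within the scatter), the first reading of this change on its own. The two values cannot be told apart in this read-out, so the growth inhibition seen with compound 2 does not depend measurably on the methoxy group at this position. Compound 4 shows that the hydroxy group, the piperazine-linked part of the core and both (2-(pyridin-2-yl)ethenyl)carbonyl groups together suffice for a value in the range of compound 2, with no methoxy group on that ring, though this is shown for this one pair alone.

The compounds shown leave open whether a different group on the same aromatic carbon, such as a fluorine atom, an amine or a longer ethoxy chain, would also read alike, and whether the same exchange would read alike in a compound that lacks the second (2-(pyridin-2-yl)ethenyl)carbonyl group. Nothing measured here speaks to why compound 2 and compound 4 read alike.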